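Compound 3 to compound 4: trifluoromethyl for chloro

This account rests on a few compounds, and the source may have more. Where it says the series, first, only, none or still open, it means among the compounds named here.

Values in an ADME assay on MRC5 cells (Homo sapiens) for cytotoxicity, read by fluorescence and resazurin assay, with a stated time of 3 days; a higher number here means a weaker inhibitor, a lower number a stronger inhibitor:
- compound 1 `Cc1cn(C2CCN(Cc3cccc(Oc4ccc(Cl)cc4)c3)CC2)c(=O)[nH]c1=O`: 25100 nM
- compound 2 `Cc1cn(C2CCN(Cc3cccc(Oc4cc(F)cc(F)c4)c3)CC2)c(=O)[nH]c1=O`: > 64000 nM, a limit of the assay
- compound 3 `Cc1cn(C2CCN(Cc3cccc(Oc4cccc(Cl)c4)c3)CC2)c(=O)[nH]c1=O`: 21000 nM

Compound 3 stands at 21000 nM, within the scatter of compound 1 at 25100 nM. Compound 2 gives only a limit, > 64000 nM.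

Compound 4 `Cc1cn(C2CCN(Cc3cccc(Oc4cccc(C(F)(F)F)c4)c3)CC2)c(=O)[nH]c1=O` differs from compound 3 by one change: trifluoromethyl in place of chloro on an aromatic carbon. Among the compounds with values here, two measured steps bear on it. With 3-chlorophenyl in place of 4-chlorophenyl, the series shows a 1.2-fold lower number from compound 1 to compound 3 (0.08 log units; within the scatter). With 3-chlorophenyl in place of 3,5-difluorophenyl, it shows an at least 3.0-fold lower number from compound 2 to compound 3 (0.48 log units; beyond the scatter), so this ring's substituents can matter. Within the data shown here, no measured step covers trifluoromethyl itself. In this assay, no step beyond the scatter is expected, though the range is kept wide. The expected change is a 1.0-fold higher number from compound 3 to compound 4 (0.02 log units; within the scatter). The estimate for compound 4 is 22000 nM, with an expected range from 9000 nM to 55000 nM.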

Compound 4, half-maximal inhibitory concentration: 12400 nM
For compound 4 the middle estimate is 1.8-fold (0.25 log units) above the measured one; the measured number falls inside the stated range.
By their numbers in this assay, from the lowest: compounds 4, 3 and 1 (each within the scatter of the next, the first and the last beyond it). At a limit, above all of these: compound 2.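

Trifluoromethyl and chloro on this aromatic carbon read alike in this assay, with a 1.7-fold lower number from compound 3 to compound 4 (0.23 log units; within the scatter). Against the 4-chlorophenyl group, however, 3-(trifluoromethyl)phenyl gives a separation that 3-chlorophenyl did not, with a 2.0-fold lower number from compound 1 to compound 4 (0.31 log units; beyond the scatter). The widest gap, an at least 5.1-fold lower number from compound 2 to compound 4 (0.71 log units; beyond the scatter), rests on a limit of the assay and not on a number: the limit of > 64000 nM in this assay, at which 1 of the 4 values shown sits.

The compounds shown leave open how an amine, a carboxylic acid or a methoxy group on this carbon would read in this assay. Trifluoromethyl on the other ring carbons also remains open.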